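A few compounds are considered here, and "the series" means these few. Any claim that something is new, unique, unknown or untested is made for them only; others in the source may bear on it.

Compound 3, `C=CCOc1cc(OC)c(C(=O)/C=C/c2ccncc2)c(OCC=C)c1`, has no number in a toxicity assay on cells (Macrophage, Mus musculus, strain BALB/c) for cytotoxicity, read by MTT assay; on this read-out lower numbers stand for stronger inhibition and higher numbers for weaker inhibition: its result there stands as "not determined" (no result reported), so its standing cannot be read from a value. The measured compounds give the only footing. Compound 1, `C=CCOc1cc(OC)c(C(=O)/C=C/Cc2ccccc2)c(OCC=C)c1`, gives 14800 nM in this assay, and compound 2, `C=CCOc1cc(OC)c(C(=O)/C=C/c2ccccc2Br)c(OCC=C)c1`, gives 5400 nM. Among the measured compounds shown here, the one step between measured compounds, a 2.7-fold lower number from compound 1 to compound 2 (0.44 log units; beyond the scatter), changes the same position that is altered here, yet with different groups, so it bears on the present step only loosely.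

Compound 4, `C=CCOc1cc(OC)c(C(=O)/C=C/c2ccc(OC)cc2)c(OCC=C)c1`, differs from compound 3 as follows: 4-methoxyphenyl in place of pyridin-4-yl on a double-bonded chain carbon bound to a double-bonded chain carbon. Both the group that leaves and the group that enters carry a single hydrogen-bond acceptor and no donor, and both are a six-membered aromatic ring on a double-bonded chain carbon bound to a double-bonded chain carbon. With no value for compound 3, no direction can be expected with any confidence; the step from compound 1 to compound 2 only shows that a change at this place can move the number modestly.

Compound 4 is therefore expected to fall near the two measured values, with an estimate of 9000 nM and a range from 2500 nM to 32000 nM, while the chance of a limit rather than a number is not small.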

Compound 4, half-maximal inhibitory concentration: 18700 nM
For compound 4 the middle estimate is 2.1-fold (0.32 log units) below the measured one; the measured number falls inside the stated range.
By their numbers in this assay, from the lowest: compound 2; then compounds 1 and 4 (each within the scatter of the next).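

In this assay, the step from compound 3 to compound 4 cannot be read, since compound 3 has no number, but compound 4 gives this position two further comparisons. With 4-methoxyphenyl in place of 2-bromophenyl, the data show a 3.5-fold higher number from compound 2 to compound 4 (0.54 log units; beyond the scatter) at this same carbon, so two six-membered aromatic rings carbon-only in make-up do not read alike here, and the mere presence of such a ring does not fix the number. With 4-methoxyphenyl in place of benzyl, the data show a 1.3-fold higher number from compound 1 to compound 4 (0.10 log units; within the scatter) and thus no separation, so the lower number seen earlier with 2-bromophenyl does not carry over to every replacement of benzyl by an aromatic ring, and compound 2 alone stands apart among the three measured compounds.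

The compounds shown leave open whether the separation of compound 2 follows from the bromine or from where the substituent sits, and how an amine or a carboxylic acid on the ring, or a longer chain in place of benzyl, would read in this assay. Nothing available here accounts for the separation of compound 2 from the other two.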